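Hydroxyphenyl placement on a pyridine series: DU-145 inhibition

The compounds below may be only part of what the source reports. "The series", "measured", "known", "first", "only" and "open" are said of these compounds alone.

Measured so far:
compound 1, `Oc1ccc(-c2cc(-c3ccc(C(F)(F)F)cc3)cc(-c3ccccc3O)n2)cc1`, > 50000 nM
compound 2, `Oc1ccccc1-c1cc(-c2ccc(OC(F)(F)F)cc2)cc(-c2ccccc2O)n1`, 20300 nM

In a functional assay on DU-145 cells (Homo sapiens) for inhibition (a lower number here means a stronger inhibitor, a higher number a weaker inhibitor), compound 1 gives only a limit, > 50000 nM; this is the limit of > 50000 nM in this assay, at which 1 of the 2 values shown sits. In this assay, going by the values given here, compound 2 gives 20300 nM, the only real number in the set, so compound 2 stands as the sole reference point. Compound 3, `Oc1ccc(-c2cc(-c3ccc(OC(F)(F)F)cc3)cc(-c3ccccc3O)n2)cc1`, carries the change 4-hydroxyphenyl in place of 2-hydroxyphenyl on an aromatic carbon. Compound 1, which also carries a 4-hydroxyphenyl, sits at the limit, so a step toward weaker inhibition is expected, a 2.0-fold higher number from compound 2 to compound 3 (0.29 log units; within the scatter), with a fair chance of another limit. Compound 3 is estimated at 40000 nM, between 15000 nM and 150000 nM.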

Compound 3, half-maximal inhibitory concentration: > 50000 nM
Compound 3 gave a limit, no number; the forecaster's own chance of this, stated with the estimate: 45%; middle value at least 1.2-fold (0.09 log units) from the limit.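

Going by these compounds alone, with 4-hydroxyphenyl in place of 2-hydroxyphenyl at the position next to the ring nitrogen, this assay shows an at least 2.4-fold higher number from compound 2 to compound 3 (0.39 log units; beyond the scatter) and so gives the first readable step. Compound 3 gives a limit, not a number, and compound 1 gives a limit too: the limit of > 50000 nM in this assay, at which 2 of the 3 values shown sit. The step between compound 1 and compound 3 cannot be read, so trifluoromethoxy and trifluoromethyl stay unseparated.

Still open, going by these compounds, is whether an amine or a carboxylic acid on the phenyl at this position would give a real number, and how that number would compare with compound 2.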